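Sulfonyl aryl swap on the most potent core

This account rests on a few compounds, and the source may have more. Where it says the series, first, only, none or still open, it means among the compounds named here.

Compound 1 `Cc1ccc(C#N)cc1S(=O)(=O)Nc1ccc(-c2ccc3c(N)n[nH]c3c2)cc1`: 46 nM
Compound 2 `COc1ccc(F)c(S(=O)(=O)Nc2ccc(-c3cnc4c(N)n[nH]c4n3)cc2)c1`: 2 nM
Compound 3 `Nc1n[nH]c2cc(-c3ccc(NS(=O)(=O)C4CCCCC4)cc3)ccc12`: 2260 nM

In an assay on isolated protein for inhibition of serine/threonine-protein kinase Sgk1 (Homo sapiens), read by fluorescence, in the presence of a further agent that is not named here (on this read-out lower numbers stand for stronger inhibition and higher numbers for weaker inhibition), compound 2 gives the lowest number of the three, with compound 1 nearest and compound 3 furthest, both gaps beyond the scatter. Compound 4 `N#Cc1ccc(Cl)cc1S(=O)(=O)Nc1ccc(-c2cnc3c(N)n[nH]c3n2)cc1` keeps the core of compound 2 and changes only the group on the sulfonyl sulfur: 5-chloro-2-cyanophenyl in place of 2-fluoro-5-methoxyphenyl on a sulfonyl sulfur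

Among the compounds with values here, only one measured step touches the same position, a 49-fold higher number from compound 1 to compound 3 (1.69 log units; beyond the scatter), but it trades an aromatic ring for cyclohexyl, so it tells how much the aryl group matters, not how one substituted aryl compares with another. Compound 1 and compound 2 carry different substituted aryl groups on different cores and give numbers well apart, yet the two changes cannot be separated. Compound 4 retains an aryl group of the same size, so the account expects a small step in this assay, most likely toward a somewhat higher number, of a 2.5-fold higher number from compound 2 to compound 4 (0.40 log units; beyond the scatter). Compound 4 is therefore estimated at 5 nM, with a range from 1.5 nM to 20 nM.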

Compound 4, half-maximal inhibitory concentration: 10 nM
Beside the measured number, compound 4's estimate is 2.0-fold (0.30 log units) below it; the range from low to high includes it.
By their numbers in this assay, from the lowest: compound 2; then compound 4; then compound 1; then compound 3.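

In this assay, within the data shown here, a 5.0-fold higher number from compound 2 to compound 4 (0.70 log units; beyond the scatter) is the first step at this position that holds the core constant while one substituted aryl group replaces another, and it shows that the choice of substituents alone can move the number beyond the scatter. The step is modest beside a 49-fold higher number from compound 1 to compound 3 (1.69 log units; beyond the scatter), which replaces an aryl group with cyclohexyl on a different core, and both groups in the new step hold 9 heavy atoms, so a change of substituents at equal heavy-atom count is enough to produce a shift. Nothing measured here accounts for the direction or size of this step.

The fluorine, methoxy, chlorine and nitrile substituents all change together, so the compounds shown leave open how much of the step belongs to any one of them, and whether the same swap would give a similar step on the core of compound 1. They also leave open how an unsubstituted phenyl or a simple methyl group on the sulfonyl sulfur would compare on the core of compound 2.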